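A few compounds are considered here, and "the series" means these few. Any claim that something is new, unique, unknown or untested is made for them only; others in the source may bear on it.

Measured so far:
compound 1 `O=C(/C=C/c1cccc(Br)n1)c1ccc(Nc2cc(-c3ccccc3)nc3nc(SCc4ccccc4)nn23)cc1` gives 38.3%
compound 2 `Cc1cc(Nc2ccc(C(=O)/C=C/c3cccc(Br)n3)cc2)n2nc(SCc3ccc(Br)cc3)nc2n1` gives 96.3%

In a functional assay on MGC-803 cells (Homo sapiens) for inhibition, read by sulforhodamine B assay, with a stated time of 72 h, tested at 10 uM (a lower number here means less inhibition, a higher number more inhibition at the concentration tested (going by the name of the read-out)), compound 2 stands highest of the two numbers, and its gap to compound 1 lies beyond the scatter. Compound 3 `Cc1cc(Nc2ccc(C(=O)/C=C/c3cccc(Br)n3)cc2)n2nc(SCCCc3ccccc3)nc2n1` differs from compound 2 in one place: phenethyl in place of 4-bromophenyl on a saturated chain carbon bound to a sulfur. Within the data shown here, no measured pair shows this kind of change, so there is no direct guide. Both groups hold one six-membered aromatic ring of carbon only, so a small loss or no step beyond the scatter is expected. Compound 3 is expected to give 80%, between 55% and 97%, an expected step of a number 16.3 percentage points lower from compound 2 to compound 3 (beyond the scatter).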

Compound 3, a percentage reported as inhibition, at one concentration (the size of the read-out at that concentration, not a potency): 76.7%
Estimate against measurement, compound 3: 3.3 percentage points above; the range from low to high includes it.
By their numbers in this assay, from the lowest: compound 1; then compound 3; then compound 2.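

In this assay, the swap on a saturated chain carbon bound to a sulfur gives a number 19.6 percentage points lower from compound 2 to compound 3 (beyond the scatter), so this position does respond to the group it carries. Even so, compound 3 keeps much of the inhibition with phenethyl in place of 4-bromophenyl, so the bromine-bearing group is not essential here. No available evidence explains the step.

The change removes the bromine and alters the chain together, and this single step cannot separate the two. On these data alone, how 4-chlorobenzyl, or a propyl chain ending in an amine, would fare at this position remains open.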